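Removing the methoxy group: compound 3 to compound 4

This account rests on a few compounds, and the source may have more. Where it says the series, first, only, none or still open, it means among the compounds named here.

Measured compounds:
compound 1, `Cc1ccccc1-n1cc(CN2C(=O)C[C@@H]3CC[C@@]2(C)C3(C)C)nn1`, 150 nM in a functional assay on OVCAR-3 cells (Homo sapiens) for inhibition, read by MTT assay, with a stated time of 24 h; a higher number here means a weaker inhibitor, a lower number a stronger inhibitor
compound 2, `COc1ccccc1-n1cc(CN2C(=O)C[C@@H]3CC[C@@]2(C)C3(C)C)nn1`, 140 nM
compound 3, `COc1ccc(-n2cc(CN3C(=O)C[C@@H]4CC[C@@]3(C)C4(C)C)nn2)cc1`, 250 nM

Compound 3 has the highest number of the three, but its gaps to compound 1, a 1.7-fold higher number from compound 1 to compound 3 (0.22 log units; within the scatter), and to compound 2, a 1.8-fold higher number from compound 2 to compound 3 (0.25 log units; within the scatter), both lie within the scatter, so no order among them can be claimed. Compound 4, `CC1(C)[C@H]2CC[C@]1(C)N(Cc1cn(-c3ccccc3)nn1)C(=O)C2`, differs from compound 3 by hydrogen in place of methoxy on an aromatic carbon. Among the measured compounds shown here, no measured step removes a group outright; the closest comparisons swap one group for another, and a 1.1-fold lower number from compound 1 to compound 2 (0.03 log units; within the scatter), like the two steps to compound 3, stayed within the scatter. On that basis the expected 1.1-fold lower number from compound 3 to compound 4 (0.04 log units; within the scatter) is no change beyond the scatter, and compound 4 is estimated at 230 nM, between 100 nM and 520 nM.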

Compound 4, half-maximal inhibitory concentration: 50 nM
Estimate against measurement, compound 4: 4.6-fold (0.66 log units) above; the measured number lies below the stated range.
By their numbers in this assay, from the lowest: compound 4; then compounds 2, 1 and 3 (each within the scatter of the next).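

In this assay, compound 4, with its unsubstituted phenyl, is the strongest inhibitor of the four, set apart from each substituted compound (a 5.0-fold lower number from compound 3 to compound 4 (0.70 log units; beyond the scatter); a 2.8-fold lower number from compound 2 to compound 4 (0.45 log units; beyond the scatter); a 3.0-fold lower number from compound 1 to compound 4 (0.48 log units; beyond the scatter)). Exchanging methyl for methoxy or changing where methoxy sat had produced no step beyond the scatter, whereas having only hydrogens on this ring does. Nothing measured here explains this gain. Still open, going by these compounds, is whether any group on this ring can keep the stronger value, or whether a fluorine or an amine would lose it as methoxy and methyl do.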